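Shortening the hydroxycarbamoyl chain: working notes on compound 4

The compounds below may be only part of what the source reports. "The series", "measured", "known", "first", "only" and "open" are said of these compounds alone.

Measured in a functional assay on MDA-MB-231 cells (Homo sapiens) for inhibition, read by MTT assay, with a stated time of 72 h; on this read-out higher numbers stand for weaker inhibition and lower numbers for stronger inhibition
- compound 1 `CNC(=O)CCCCCCCn1nc(-c2cnc3[nH]ccc3c2)c2c(N)ncnc21` gives 15800 nM
- compound 2 `Nc1ncnc2c1c(-c1cnc3[nH]ccc3c1)nn2CC(=O)NO` gives > 150000 nM as a limit of the assay
- compound 3 `Nc1ncnc2c1c(-c1cnc3[nH]ccc3c1)nn2CCCCCCCCCC(=O)NO` gives 10100 nM

Going by the values given here, compound 3 stands level with compound 1 within the scatter, and these two hold the only true numbers in the set. Compound 4 `Nc1ncnc2c1c(-c1cnc3[nH]ccc3c1)nn2CCCC(=O)NO` departs from compound 3 in one place, with hydroxycarbamoyl in place of 6-(hydroxycarbamoyl)hexyl on a saturated chain carbon, three bonds along the chain from an aromatic nitrogen.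

Among the compounds with values here, two measured steps bear on this change. The step of a 1.6-fold lower number from compound 1 to compound 3 (0.19 log units; within the scatter) stays within the scatter and gives no size to work from. On these data alone, the step of an at least 9.4-fold higher number from compound 1 to compound 2 (0.97 log units; beyond the scatter) is the closer guide, as it puts hydroxycarbamoyl on a much shorter chain and ends at a limit, so its true size remains open. A higher number beyond the scatter is therefore expected, though probably short of that limit. The expected step is a 5.9-fold higher number from compound 3 to compound 4 (0.77 log units; beyond the scatter) in this assay and rests on that comparison. For compound 4 the estimate is 60000 nM with an expected range from 20000 nM to 150000 nM in this assay.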

Compound 4, half-maximal inhibitory concentration: > 150000 nM
Compound 4: only a limit was reported (the forecaster's own chance of this, stated with the estimate: 30%); at least 2.5-fold (0.39 log units) between middle value and limit.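

In this assay compound 4 gives > 150000 nM, which is a limit of the assay and not a number. Removing the 6-(hydroxycarbamoyl)hexyl portion thus costs a large step, an at least 14-fold higher number from compound 3 to compound 4 (1.17 log units; beyond the scatter), so keeping the hydroxycarbamoyl group does not preserve a measurable value once the chain is this short. Against the methylcarbamoyl compound the change reads an at least 9.4-fold higher number from compound 1 to compound 4 (0.97 log units; beyond the scatter), which shows that the loss already appears at this chain length and not only on the shorter chain of compound 2.

The step from compound 2 to compound 4 cannot be read, as both values are the same limit: the limit of > 150000 nM in this assay, at which 2 of the 4 values shown sit. Open is which chain of intermediate length restores a true number, and what a carboxylic acid in place of hydroxycarbamoyl, or a longer chain than that of compound 3, would give.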